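The compounds below may be only part of what the source reports. "The series", "measured", "known", "first", "only" and "open" are said of these compounds alone.

Compound 3 `COc1ccc(/C=C/C[C@@H]2C[C@@H]([C@@H](OC)c3ccc(OC)c(OC)c3)CO[C@H]2c2ccc(OC)c(OC)c2)cc1OC` carries a methyl on the oxygen on a saturated carbon, and in a functional assay on HeLa cells (Homo sapiens) for cytotoxicity, read by WST assay, with a stated time of 48 h (on this read-out higher numbers stand for weaker inhibition and lower numbers for stronger inhibition), compound 3 gives > 100000 nM, which is a limit of the assay rather than a measured number. This is the limit of > 100000 nM in this assay, at which 1 of the 3 values shown sits. Compound 4 `COc1ccc(/C=C/C[C@@H]2C[C@@H]([C@@H](O)c3ccc(OC)c(OC)c3)CO[C@H]2c2ccc(OC)c(OC)c2)cc1OC` differs from compound 3 at exactly that spot: hydrogen in place of methyl on an oxygen on a saturated carbon. Going by the values given here, no measured pair shows this particular change. The closest guide comes from compound 1 `COc1ccc([C@H](O)[C@H]2CO[C@@H](c3ccc(OC)c(OC)c3)[C@H](C/C=C/c3ccccc3)C2)cc1OC` and compound 2 `COc1cccc(/C=C/C[C@@H]2C[C@@H]([C@@H](O)c3ccc(OC)c(OC)c3)CO[C@H]2c2ccc(OC)c(OC)c2)c1`, which both carry the same hydroxy that compound 4 carries. In this assay compound 1 gives 16100 nM and compound 2 gives 16400 nM. Among the compounds with values here, the one measured step, a 1.0-fold higher number from compound 1 to compound 2 (0.01 log units; within the scatter), concerns a different change, methoxy in place of hydrogen on an aromatic carbon, and shows that this change leaves the read-out essentially unchanged. Compound 4 combines the hydroxy of compounds 1 and 2 with the aromatic substitution of compound 3, so its number is expected to return to the region of compounds 1 and 2 because compound 1 gives 16100 nM and compound 2 gives 16400 nM. The expected step is therefore an at least 5.5-fold lower number from compound 3 to compound 4 (0.74 log units; beyond the scatter), a drop from the limit. Compound 4 is estimated at 18000 nM, with a likely range from 7000 nM to 50000 nM.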

Compound 4, half-maximal inhibitory concentration: 30600 nM
Beside the measured number, compound 4's estimate is 1.7-fold (0.23 log units) below it, within the range that was stated.
By their numbers in this assay, from the lowest: compounds 1, 2 and 4 (each within the scatter of the next). At a limit, above all of these: compound 3.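

In this assay, going by these compounds alone, the first measured pair for this change gives an at least 3.2-fold lower number from compound 3 to compound 4 (0.51 log units; beyond the scatter), so the read-out does respond to hydrogen in place of methyl on the oxygen on this saturated carbon, and the true size of the step could be larger. Compound 3 stands at a limit of the assay and not at a measured number: the limit of > 100000 nM in this assay, at which 1 of the 4 values shown sits. The aromatic end of the molecule behaves differently, as a 1.9-fold higher number from compound 2 to compound 4 (0.27 log units; within the scatter) and a 1.9-fold higher number from compound 1 to compound 4 (0.28 log units; within the scatter) both lie within the scatter, so compounds 1, 2 and 4 cannot be told apart even though their aromatic substitution differs.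

On these data alone, whether the read-out needs a hydroxy at this spot or merely tolerates small groups there stays open, and an amine in its place, or an ethyl in place of the methyl on the oxygen, would help to separate these two readings. As far as these compounds go, it is also open whether the aromatic end stays this insensitive with a quite different group on it, such as a carboxylic acid.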